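The compounds below may be only part of what the source reports. "The series", "measured", "known", "first", "only" and "open" are said of these compounds alone.

Measured in a functional assay on HCT-116 cells (Homo sapiens) for antiproliferative activity; a lower number here means a stronger inhibitor, a higher number a weaker inhibitor:
- compound 1 `Cc1c2c(n3c1CCCNC[C@H](C)Nc1cc-3ccc1C(N)=O)CC(C)(C)CC2=O`: 93 nM
- compound 2 `CC(=O)N1CCCc2c(C)c3c(n2-c2ccc(C(N)=O)c(c2)N[C@@H](C)[C@@H]1C)CC(C)(C)CC3=O`: 27 nM
- compound 3 `CC(=O)N1CCc2c(C)c3c(n2-c2ccc(C(N)=O)c(c2)N[C@@H](C)[C@H](C)C1)CC(C)(C)CC3=O`: 24 nM

Compound 2 at 27 nM lies within the scatter of compound 3 at 24 nM. Compound 2 at 27 nM has a lower number than compound 1 at 93 nM, and that gap is beyond the scatter. For the measured compounds named here, three compounds make a narrow base, and no measured pair differs in one place only.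

The next compound is compound 4 `Cc1c2c(n3c1CCCN(C(=O)CN)[C@@H](C)[C@H](C)Nc1cc-3ccc1C(N)=O)CC(C)(C)CC2=O`. It departs from compound 2 by amino in place of hydrogen on a saturated chain carbon bound to a carbonyl carbon, so acetyl becomes (aminomethyl)carbonyl. Going by the values given here, no measured compound shows the effect of this change, so the expectation is loose. It is anchored on compound 2 at 27 nM. In this assay no step beyond the scatter is expected, in either direction, and the estimated change is a 1.1-fold higher number from compound 2 to compound 4 (0.05 log units; within the scatter). For compound 4 the estimated value is 30 nM, with an expected range of 10 nM to 90 nM.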

Compound 4, half-maximal inhibitory concentration: 147 nM
The estimate for compound 4 lay 4.9-fold (0.69 log units) below the measured number, outside the stated range (above it).
By their numbers in this assay, from the lowest: compounds 3 and 2 (each within the scatter of the next); then compounds 1 and 4 (each within the scatter of the next).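

Acetyl to (aminomethyl)carbonyl gives the first comparison in the series that differs in one place only, and in this assay it reads as a loss: a 5.4-fold higher number from compound 2 to compound 4 (0.74 log units; beyond the scatter), beyond the scatter. Amino in place of hydrogen on this saturated chain carbon bound to a carbonyl carbon is therefore not a neutral change, at least in the setting of compound 2, and the position responds to a single added heavy atom. No measurement among the data given accounts for this loss.

For the compounds shown here, the single pair leaves open whether the loss belongs to the amino group itself or to any substituent on this carbon. Hydroxy, methoxy, dimethylamino or a longer chain such as 2-aminoethyl at the same place would separate these readings.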